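This account rests on a few compounds, and the source may have more. Where it says the series, first, only, none or still open, it means among the compounds named here.

Measured so far: compound 1, `Cc1cc(O)cc(-c2nn(CC#N)cc2-c2ccnc(-c3ccc(Oc4ccccc4)cc3)c2)c1`, and compound 2, `COc1cc(C)cc(-c2nn(CC#N)cc2-c2ccnc(-c3ccc(N(C)C)cc3)c2)c1`. In a functional assay on MOLT-4 cells (Homo sapiens) for inhibition, read by sulforhodamine B assay, with a stated time of 48 h (a higher number here means a weaker inhibitor of growth, a lower number a stronger inhibitor of growth), compound 1 gives 6820 nM. In this assay compound 2 gives only a limit of the assay, > 100000 nM, which is the limit of > 100000 nM in this assay, at which 1 of the 2 values shown sits. Compound 2 therefore stands at the weak end of the two values shown. Compound 3, `Cc1cc(O)cc(-c2nn(CC#N)cc2-c2ccnc(-c3ccc(N(C)C)cc3)c2)c1`, differs from compound 2 by hydrogen in place of methyl on an oxygen on an aromatic ring. Within the data shown here, no step between measured compounds shows what this change does; compound 1 carries the hydroxy but also a different group on the other ring, so its value is no direct guide. Compound 3 is expected to stay weak, with a step of an at least 1.6-fold lower number from compound 2 to compound 3 (0.22 log units; that floor lies within the scatter) that may not exceed the scatter. The estimate for compound 3 is 60000 nM, between 12000 nM and 150000 nM.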

Compound 3, concentration for total growth inhibition: 46000 nM
Compound 3: middle estimate off by 1.3-fold (0.12 log units), on the high side; measured number inside the range.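

In this assay, among these compounds, methoxy to hydroxy on the aromatic ring gives an at least 2.1-fold lower number from compound 2 to compound 3 (0.33 log units; beyond the scatter), a change the earlier compounds could not isolate. This size is only a floor, since the value of compound 2 is a limit: the limit of > 100000 nM in this assay, at which 1 of the 3 values shown sits. With the hydroxy held constant, the group on the other ring can now be read alone, and dimethylamino in place of phenoxy gives a 6.7-fold higher number from compound 1 to compound 3 (0.83 log units; beyond the scatter).

The compounds shown leave open how an ethoxy group or an amine would compare on that oxygen. They also leave open whether methoxy to hydroxy gives a similar step when phenoxy is present.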